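Removing a methoxy from a growth-inhibiting compound

This account rests on a few compounds, and the source may have more. Where it says the series, first, only, none or still open, it means among the compounds named here.

In a functional assay on COLO 205 cells (Homo sapiens) for inhibition, read by sulforhodamine B assay, with a stated time of 48 h, tested at 50 uM (a lower number here means less inhibition of growth, a higher number more inhibition of growth at the concentration tested), compound 1 `COc1cc(/C=C/C(=O)/C=C/c2cccs2)ccc1OCc1cn(CCOc2cc(=O)oc3ccccc23)nn1` gives 66% of inhibition and compound 2 `COc1ccccc1/C=C/C(=O)/C=C/c1ccc(OCc2cn(CCCOc3cc(=O)oc4ccccc34)nn2)c(OC)c1` gives 57% of inhibition, so the two stand within the usual scatter of each other. Compound 3 `COc1cc(/C=C/C(=O)/C=C/c2ccccc2)ccc1OCc1cn(CCCOc2cc(=O)oc3ccccc23)nn1` differs from compound 2 by a single change hydrogen in place of methoxy on an aromatic carbon that puts hydrogen in place of methoxy on an aromatic carbon, turning 2-methoxyphenyl into phenyl. Among the measured compounds shown here, no measured pair shows this change on its own. An expected step of a number 1 percentage points higher from compound 2 to compound 3 (within the scatter) in this assay would stay within the scatter, with neither direction favoured. In this assay compound 3 is estimated at 58% with a range from 42% to 72% at the concentration tested.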

Compound 3, percent growth inhibition at one concentration: 43%
Estimate against measurement, compound 3: 15 percentage points above; low and high end bracket the measured number.
By their numbers in this assay, from the lowest: compound 3; then compounds 2 and 1 (each within the scatter of the next).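

Replacing methoxy with hydrogen on this aromatic carbon, ortho to a large group, turns 2-methoxyphenyl into phenyl and gives a number 14 percentage points lower from compound 2 to compound 3 (beyond the scatter) in this assay, so what this carbon carries can register in growth inhibition. Compounds 1 and 2 could not show this, since they differ in more than one place and their values lie within the scatter of each other. Nothing available explains the step. The compounds shown leave open whether a hydroxyl, a fluorine or an amine on this carbon would hold the inhibition of compound 2 or follow compound 3.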